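The source may hold more compounds than are shown below. What is called first, only, known or untested is meant among the compounds shown, and "the series" means these compounds.

Compound 1, `CCCC(Oc1ccc(-n2cc(C(F)(F)F)c(C)n2)cc1)c1ccc(C(=O)NCCC(=O)O)cc1`, in a functional assay on cells for antagonist activity at Glucagon receptor (Homo sapiens), read by cAMP accumulation, in the presence of a further agent that is not named here; a lower number here means a stronger inhibitor, a higher number a weaker inhibitor: 8300 nM
Compound 2, `CCCC(Oc1ccc(-n2cc3c(n2)CCCC3)cc1)c1ccc(C(=O)NCCC(=O)O)cc1`: 4200 nM
Compound 3, `CCCC(Oc1ccc(-n2cc(C)cn2)cc1)c1ccc(C(=O)NCCC(=O)O)cc1`: 11000 nM

Compound 3 carries the highest number of the three. Its nearest neighbour is compound 1, and the pair differ by a 1.3-fold higher number from compound 1 to compound 3 (0.12 log units; within the scatter), a gap that lies within the usual scatter of repeated measurements. The furthest step is a 2.6-fold higher number from compound 2 to compound 3 (0.42 log units; beyond the scatter), modest but beyond the scatter.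

Compound 4, `CCCC(Oc1ccc(-n2cc(Cl)cn2)cc1)c1ccc(C(=O)NCCC(=O)O)cc1`, is the next compound to consider. Its difference from compound 3 is chloro in place of methyl on an aromatic carbon. Among the compounds with values here, no measured step swaps one small substituent for another at that ring carbon; the measured steps instead exchange whole substitution patterns on the pyrazole, and even those moved the number only by a 1.3-fold higher number from compound 1 to compound 3 (0.12 log units; within the scatter) and a 2.6-fold higher number from compound 2 to compound 3 (0.42 log units; beyond the scatter). A change of a single atom at the same position is therefore expected to do no more than that, with no clear direction to call.

Compound 4 is expected to give about 9000 nM in this assay, with a likely range from 4000 nM to 20000 nM. The expected step, a 1.2-fold lower number from compound 3 to compound 4 (0.09 log units; within the scatter), is estimated to stay within the scatter.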

Compound 4, antagonist equilibrium constant: 6500 nM
Compound 4: the middle estimate sits 1.4-fold (0.14 log units) above what was measured; low and high end bracket the measured number.
By their numbers in this assay, from the lowest: compounds 2, 4, 1 and 3 (each within the scatter of the next, the first and the last beyond it).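

In this assay, within the data shown here, chloro in place of methyl on this aromatic carbon of the pyrazole gives a 1.7-fold lower number from compound 3 to compound 4 (0.23 log units; within the scatter); this is the first measured exchange of one single atom for another at that ring carbon, and the step stays within the scatter. The 4-chloro-1H-pyrazol-1-yl group also cannot be separated from the two larger groups, since a 1.5-fold higher number from compound 2 to compound 4 (0.19 log units; within the scatter) and a 1.3-fold lower number from compound 1 to compound 4 (0.11 log units; within the scatter) both lie within the scatter, so neither pair can be put in order. Nothing available on these compounds offers a reason for these numbers.

Still open, on these data alone, is whether a group of another kind on this ring carbon, such as an amine, a nitrile or a carboxylic acid, would shift the number beyond the scatter from compound 4. Among these compounds, also open is whether chloro and methyl would remain this close on a version of the core with a longer chain in place of the one all four compounds share.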